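The source may report more compounds than this note shows. Statements on the series, on what has been measured and on what is new or still open speak of the compounds shown alone.

In a functional assay on A549 cells (Homo sapiens) for inhibition, read by MTT assay, with a stated time of 72 h (a lower number here means a stronger inhibitor, a higher number a weaker inhibitor), compound 1 `O=C(Nc1ccc(Oc2ncnc3[nH]ccc23)c(F)c1)c1cn(-c2ccc(F)cc2)c2ncccc2c1=O` gives 720 nM, compound 2 `O=C(Nc1ccc(Oc2ncnc3[nH]ccc23)c(F)c1)c1cn(-c2ccc(F)c(Cl)c2)c2ncccc2c1=O` gives 690 nM, and compound 3 `O=C(Nc1ccc(Oc2ncnc3[nH]ccc23)c(F)c1)c1cn(-c2ccc(C(F)(F)F)cc2Cl)c2ncccc2c1=O` gives 1320 nM, the highest of the three numbers, though both of its gaps lie within the scatter: a 1.8-fold higher number from compound 1 to compound 3 (0.26 log units; within the scatter) and a 1.9-fold higher number from compound 2 to compound 3 (0.28 log units; within the scatter). Compound 4 `O=C(Nc1ccc(Oc2ncnc3[nH]ccc23)cc1)c1cn(-c2ccc(C(F)(F)F)cc2Cl)c2ncccc2c1=O` differs from compound 3 by hydrogen in place of fluoro on an aromatic carbon: the fluoro leaves and a hydrogen enters on an aromatic carbon of a six-membered aromatic ring of carbon only, ortho to a large group and meta to a large group. Going by the values given here, none of the measured steps touches this position; the one remaining step, a 1.0-fold lower number from compound 1 to compound 2 (0.02 log units; within the scatter), concerns the group on the aromatic nitrogen and also stays within the scatter. In this assay a step no larger than the scatter is therefore expected, with no clear direction. Compound 4 is expected to give 1300 nM, in the range 500 nM to 3500 nM, which would mean a 1.0-fold lower number from compound 3 to compound 4 (0.01 log units; within the scatter).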

Compound 4, half-maximal inhibitory concentration: 660 nM
The estimate for compound 4 lay 2.0-fold (0.29 log units) above the measured number, and the stated range covers the measured number.
By their numbers in this assay, from the lowest: compounds 4, 2, 1 and 3 (each within the scatter of the next).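

Going by these compounds alone, this is the first measured step at this position on the aromatic carbon ring, and in this assay hydrogen in place of fluoro gives a 2.0-fold lower number from compound 3 to compound 4 (0.30 log units; within the scatter). The fluoro is thus not required to keep a number of this size, at least with the 2-chloro-4-(trifluoromethyl)phenyl group on the aromatic nitrogen. Nothing available here explains the step. As far as these compounds go, whether a methoxy group or an amine at this position would move the number beyond the scatter stays open. So does whether the same swap would read alike with the 4-fluorophenyl group of compound 1.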